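The source may report more compounds than this note shows. Statements on the series, on what has been measured and on what is new or still open speak of the compounds shown alone.

Measured compounds in a functional assay on K562 cells (Homo sapiens) for inhibition, read by trypan blue exclusion, with a stated time of 72 h; on this read-out higher numbers stand for weaker inhibition and lower numbers for stronger inhibition:
compound 1 `Cn1c(=O)c(S(=O)(=O)c2ccc(F)cc2[N+](=O)[O-])cc2cnc(Nc3ccc4[nH]ccc4c3)nc21` gives 900 nM;
compound 2 `Cn1c(=O)c(S(=O)(=O)Cc2ccc(F)cc2F)cc2cnc(Nc3ccc4[nH]ccc4c3)nc21` gives 1000 nM;
compound 3 `Cn1c(=O)c(S(=O)(=O)Cc2ccc(F)cc2)cc2cnc(Nc3ccc4[nH]ccc4c3)nc21` gives 30000 nM.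

Compound 3 gives the highest number of the three; compound 2 lies nearest, with a 30-fold higher number from compound 2 to compound 3 (1.48 log units; beyond the scatter), and compound 1 furthest, with a 33-fold higher number from compound 1 to compound 3 (1.52 log units; beyond the scatter). Compound 4 `Cn1c(=O)c(S(=O)(=O)c2ccc([N+](=O)[O-])cc2F)cc2cnc(Nc3ccc4[nH]ccc4c3)nc21` differs from compound 3 thus: 2-fluoro-4-nitrophenyl in place of 4-fluorobenzyl on a sulfonyl sulfur. Within the data shown here, the group entering is a regioisomer of the fluoro-nitrophenyl in compound 1, and no measured step separates the two arrangements. The step bearing directly is the large one from compound 1 to compound 3; reversing it at the same sulfonyl sulfur suggests a large step down for compound 4 in this assay, with the regioisomerism unresolved. The expected step is a 20-fold lower number from compound 3 to compound 4 (1.30 log units; beyond the scatter), so compound 4 is estimated at 1500 nM, within 400 nM to 6000 nM.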

Compound 4, half-maximal inhibitory concentration: 200 nM
Estimate against measurement, compound 4: 7.5-fold (0.88 log units) above; the whole stated range lies above it.
By their numbers in this assay, from the lowest: compound 4; then compounds 1 and 2 (each within the scatter of the next); then compound 3.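

Fluoro and nitro placement on the phenyl ring matters at this sulfonyl sulfur: 2-fluoro-4-nitrophenyl separates from its regioisomer 4-fluoro-2-nitrophenyl (a 4.5-fold lower number from compound 1 to compound 4 (0.65 log units; beyond the scatter)). The same group also surpasses 2,4-difluorobenzyl (a 5.0-fold lower number from compound 2 to compound 4 (0.70 log units; beyond the scatter)) and gives the largest step in the series against 4-fluorobenzyl (a 150-fold lower number from compound 3 to compound 4 (2.18 log units; beyond the scatter)). Nothing available explains these differences. Open: whether an amine or a nitrile in place of the nitro group holds this potency, and whether 2-fluoro-4-nitrobenzyl on the same sulfonyl sulfur matches the phenyl group.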